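The source may hold more compounds than are shown below. What is called first, only, known or untested is meant among the compounds shown, and "the series" means these compounds.

Series so far, in a functional assay on HUVEC cells (Homo sapiens), read by BrdU incorporation, with a stated time of 72 h; a lower number here means a stronger inhibitor, a higher number a weaker inhibitor 
compound 1 `Cc1ccc2nc(Cl)c(/C=C/C(=O)c3sccc3C)cc2c1` at 127 nM 
compound 2 `Cc1cccc2cc(/C=C/C(=O)c3ccc(Cl)s3)c(Cl)nc12` at 116 nM 

Compound 1 at 127 nM and compound 2 at 116 nM lie within the scatter of each other. The two numbers therefore give no order, and compound 1 sits level with the only other measured point.

Next in view is compound 3 `Cc1ccc2nc(Cl)c(/C=C/C(=O)c3sccc3Br)cc2c1`, which keeps the core of compound 1 and changes one group: bromo in place of methyl on an aromatic carbon. In words, this is bromo in place of methyl on an aromatic carbon, 3-methylthiophen-2-yl to 3-bromothiophen-2-yl.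

Within the data shown here, no measured pair shows this change, or any other change in a single place, so the data give no direct size for it. No shift beyond the scatter is expected in this assay, and neither direction is favoured. The expected 1.1-fold lower number from compound 1 to compound 3 (0.02 log units; within the scatter) is an estimate resting on the structural change alone. Among the measured compounds shown here, no measured step is available to narrow the range, so it is kept wide. Compound 3 is expected at 120 nM, with an estimated range from 45 nM to 320 nM in this read-out.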

Compound 3, half-maximal inhibitory concentration: 61.9 nM
The estimate for compound 3 lay 1.9-fold (0.29 log units) above the measured number; the measured number falls inside the stated range.
By their numbers in this assay, from the lowest: compounds 3, 2 and 1 (each within the scatter of the next, the first and the last beyond it).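

In this assay, among these compounds, the exchange of 3-methylthiophen-2-yl for 3-bromothiophen-2-yl provides the first step that differs in one place only (a 2.1-fold lower number from compound 1 to compound 3 (0.31 log units; beyond the scatter)). This shows that the substituent on this aromatic carbon, next to the ring atom that bears a large group and two ring bonds from the ring sulfur, can move the number beyond the scatter, although the step is modest and rests on a single pair. The exchange replaces one heavy atom with one heavy atom and leaves the hydrogen-bond donor and acceptor counts and net charge unchanged, so these counts do not separate compound 1 from compound 3, and nothing available explains the difference.

With only methyl and bromo shown at this position, it remains open whether fluoro, chloro, methoxy, an amine or a carboxylic acid would give a lower or a higher number. As far as these compounds go, it also remains open whether bromo in place of methyl would give a step of similar size and the same direction on a different core.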